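A few compounds are considered here, and "the series" means these few. Any claim that something is new, unique, unknown or untested is made for them only; others in the source may bear on it.

Compound 1 `CC1=C(C(=O)Nc2ccc(F)cc2)C(c2ccc([N+](=O)[O-])cc2)N=C(SCc2cccc(Cl)c2)N1` and compound 2 `CC1=C(C(=O)Nc2ccc(F)cc2)C(c2ccc([N+](=O)[O-])cc2)N=C(SCc2ccc(Cl)cc2)N1` share one core, and compound 2 differs from compound 1 only in that (4-chlorophenyl in place of 3-chlorophenyl on a saturated chain carbon bound to a sulfur). In a functional assay on the whole organism (artery, strain albino) with Rattus norvegicus as the target, with a stated time of 30 min, at a dose of 10 mg/kg by the oral route (a lower number here means less inhibition, a higher number more inhibition at the dose given (going by the name of the read-out)), compound 1 gives 4.1%, and compound 2 gives 6.7%; the step of a number 2.6 percentage points higher from compound 1 to compound 2 (within the scatter). Compound 3 `CC1=C(C(=O)Nc2ccc(Br)cc2)C(c2ccc(Cl)cc2Cl)N=C(SCc2cccc(Cl)c2)N1` rests on another core; how its core differs from that of compound 1 is not broken down here. In this assay compound 3 gives 3.1%, a number within the scatter of both compound 1 and compound 2. Compound 4 `CC1=C(C(=O)Nc2ccc(Br)cc2)C(c2ccc(Cl)cc2Cl)N=C(SCc2ccc(Cl)cc2)N1` has not been measured; it differs from compound 3 in that (4-chlorophenyl in place of 3-chlorophenyl on a saturated chain carbon bound to a sulfur), at the same place as the change from compound 1 to compound 2. The expected step of a number 1.9 percentage points higher from compound 3 to compound 4 (within the scatter) rests on the earlier step of a number 2.6 percentage points higher from compound 1 to compound 2 (within the scatter) lying within the scatter. Compound 4 is therefore expected to give about 5%, with a range from 0% to 12%.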

Compound 4, a percentage reported as inhibition, in the whole organism at one dose (the size of the read-out at that dose, not a potency): 6.7%
For compound 4 the middle estimate is 1.7 percentage points below the measured one, within the range that was stated.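

On the core of the later pair, 4-chlorophenyl in place of 3-chlorophenyl on a saturated chain carbon bound to a sulfur gives a number 3.6 percentage points higher from compound 3 to compound 4 (within the scatter). In this assay the change reads alike on the two cores: the same change on two cores in this assay, a number 2.6 percentage points higher (within the scatter) from compound 1 to compound 2 and a number 3.6 percentage points higher (within the scatter) from compound 3 to compound 4, 1 percentage points apart, within the scatter of two such steps

This shows that the two steps agree, but it does not show that the change has an effect of its own on either core, as each step lies within the scatter. A real effect carried from one core to another therefore cannot be claimed.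

The compounds shown leave open how an unsubstituted phenyl, an amine or a carboxylic acid at that place would read in this assay. They also leave open whether a longer chain between the sulfur and the ring would give a step beyond the scatter.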